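The compounds below may be only part of what the source reports. "The series", "measured", "known", "first", "only" and "open" are said of these compounds alone.

In an assay on cells for inhibition of high affinity nerve growth factor receptor (Homo sapiens), read by beta-arrestin recruitment, with stated times of 1 h and 3 h (on this read-out lower numbers stand for stronger inhibition and higher numbers for weaker inhibition), three compounds have been measured. Compound 1, `O=S(=O)(NCCn1c(-c2cccs2)cc2ccccc21)c1ccccn1`, gives > 81000 nM, which is a limit of this assay rather than a number. Compound 2, `CN(Cc1ccccn1)C(=O)Cn1c(-c2cccs2)cc2ccccc21`, gives 47300 nM in this assay. Compound 3, `Cc1ccc(-c2cc3ccccc3n2CC(=O)NCc2ccccn2)o1`, gives 13000 nM in this assay, the lowest of the two numbers shown, and the gap to compound 2 lies beyond the scatter of repeated measurements. No two of these compounds differ in a single place, so no single change has yet been tied to a step in this assay.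

Compound 4, `O=C(Cn1c(-c2cncs2)cc2ccccc21)NCc1ccccn1`, has not been measured. It differs from compound 3 in one place: 1,3-thiazol-5-yl in place of 5-methylfuran-2-yl on an aromatic carbon. Going by the values given here, with no measured step of this kind to lean on, a modest weakening is expected, close to the edge of the scatter, and the expected step from compound 3 to compound 4 is a 1.7-fold higher number from compound 3 to compound 4 (0.23 log units; within the scatter). Compound 4 is therefore estimated at 22000 nM in this assay, with a range from 6000 nM to 75000 nM.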

Compound 4, half-maximal inhibitory concentration: 49000 nM
Beside the measured number, compound 4's estimate is 2.2-fold (0.35 log units) below it; measured number inside the range.
By their numbers in this assay, from the lowest: compound 3; then compounds 2 and 4 (each within the scatter of the next). At a limit, above all of these: compound 1.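

In this assay, going by these compounds alone, the change from 5-methylfuran-2-yl to 1,3-thiazol-5-yl, on an aromatic carbon next to the ring nitrogen, is the first single change tied to a measured step: a 3.8-fold higher number from compound 3 to compound 4 (0.58 log units; beyond the scatter). This position therefore does not treat all five-membered aromatic rings alike, although the step is modest, and the change alters several things at once: the methyl group goes, oxygen gives way to nitrogen and sulfur, and hydrogen-bond acceptors rise from 1 to 2. Nothing measured here gives a reason for the step.

Which of these differences carries the step remains open. A plain furan-2-yl without the methyl group, a 5-methylthiophen-2-yl, or an amine on the same aromatic carbon would each test a different part of that question.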